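Changing the aryl group on a pyrimidine urea series

A few compounds are considered here, and "the series" means these few. Any claim that something is new, unique, unknown or untested is made for them only; others in the source may bear on it.

Measured compounds:
compound 1, `COc1ccc(F)cc1Nc1cc(NC(=O)Nc2c(Cl)cccc2Cl)ncn1`: 85.5%
compound 2, `Cc1ccc(Nc2cc(NC(=O)Nc3c(Cl)cccc3Cl)ncn2)cc1C`: 92.1%

In a functional assay on PC-9 cells (Homo sapiens) for inhibition, read by MTT assay, with a stated time of 48 h, tested at 10 uM (a higher number here means more inhibition at the concentration tested (going by the name of the read-out), a lower number less inhibition), compound 1 (`COc1ccc(F)cc1Nc1cc(NC(=O)Nc2c(Cl)cccc2Cl)ncn1`) gives 85.5%, and compound 2 (`Cc1ccc(Nc2cc(NC(=O)Nc3c(Cl)cccc3Cl)ncn2)cc1C`) gives 92.1%. Going by the values given here, compound 2 has one of only two numbers, and the step of a number 6.6 percentage points higher from compound 1 to compound 2 (within the scatter) is within the scatter, so the two compounds cannot be told apart on this assay.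

Compound 3 (`Cc1cc(F)cc(Nc2cc(NC(=O)Nc3c(Cl)cccc3Cl)ncn2)c1`) differs from compound 2 by 3-fluoro-5-methylphenyl in place of 3,4-dimethylphenyl on a nitrogen on an aromatic ring. Among the compounds with values here, the only measured step that bears on this, a swap of the group on the same nitrogen, was a number 6.6 percentage points higher from compound 1 to compound 2 (within the scatter), within the scatter. The step of a number 6.1 percentage points lower from compound 2 to compound 3 (within the scatter) is therefore expected to stay within the scatter. Compound 3 is estimated to give 86%, between 72% and 96%.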

Compound 3, a percentage reported as inhibition, at one concentration (the size of the read-out at that concentration, not a potency): 80%
Compound 3: middle estimate off by 6 percentage points, on the high side; low and high end bracket the measured number.
By their numbers in this assay, from the lowest: compounds 3, 1 and 2 (each within the scatter of the next, the first and the last beyond it).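

In this assay the aryl group on this nitrogen now gives a step beyond the scatter: a number 12.1 percentage points lower from compound 2 to compound 3 (beyond the scatter) when 3-fluoro-5-methylphenyl replaces 3,4-dimethylphenyl. The other new step, a number 5.5 percentage points lower from compound 1 to compound 3 (within the scatter) when 3-fluoro-5-methylphenyl replaces 5-fluoro-2-methoxyphenyl, stays within the scatter, so compound 1 cannot be separated from compound 3 or from compound 2. Nothing available explains the gap between compound 2 and compound 3.

Going by these compounds, it remains open whether the number in this assay would be higher, lower or level with a group other than a substituted phenyl on this nitrogen, such as a cyclohexyl ring or a pyridine. The effect of a carboxylic acid or an amine on the phenyl ring is also unknown.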